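Swapping propyl for cyclohexyl on a shared core

The source may report more compounds than this note shows. Statements on the series, on what has been measured and on what is new or still open speak of the compounds shown alone.

In a functional assay on K562 cells (Homo sapiens) for inhibition, read by trypan blue exclusion, with a stated time of 72 h (a lower number here means a stronger inhibitor, a higher number a weaker inhibitor), compound 1 (`CCCn1c(=O)c(S(=O)(=O)c2ccc(F)cc2F)cc2cnc(Nc3ccc4[nH]ccc4c3)nc21`) gives 1000 nM as its result. Also in this assay compound 2 (`Cn1c(=O)c(S(=O)(=O)c2ccc(F)cc2F)cc2cnc(Nc3cccc4[nH]ccc34)nc21`) gives 1500 nM and compound 3 (`Cn1c(=O)c(S(=O)(=O)c2ccc(F)cc2)cc2cnc(Nc3cccc4[nH]ccc34)nc21`) gives 750 nM so all three values lie within the usual scatter of one another.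

Compound 4 (`O=c1c(S(=O)(=O)c2ccc(F)cc2F)cc2cnc(Nc3ccc4[nH]ccc4c3)nc2n1C1CCCCC1`) is compound 1 with cyclohexyl in place of propyl on an aromatic nitrogen and nothing else altered. Among the measured compounds shown here, no measured step isolates a change of the group on that nitrogen. For the measured compounds named here, the only single-place step is a 2.0-fold lower number from compound 2 to compound 3 (0.30 log units; within the scatter) and it concerns hydrogen in place of fluoro on an aromatic carbon, so it bears only loosely on this swap. It does show that one small edit left the number within the scatter, but it offers no direction for a larger group on the nitrogen.

No step beyond the scatter is therefore expected in this assay and no direction is favoured. For compound 4 the estimated step is a 1.1-fold lower number from compound 1 to compound 4 (0.05 log units; within the scatter) in this reading. For compound 4 the expected value is 900 nM with an estimated range of 300 nM to 2700 nM around it.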

Compound 4, half-maximal inhibitory concentration: 10000 nM
Compound 4: the middle estimate sits 11-fold (1.05 log units) below what was measured; the measured number lies above the stated range.
By their numbers in this assay, from the lowest: compounds 3, 1 and 2 (each within the scatter of the next); then compound 4.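

In this assay, the group on this aromatic nitrogen proves able to change the result: moving from propyl to cyclohexyl gives a 10-fold higher number from compound 1 to compound 4 (1.00 log units; beyond the scatter) and is the first step among these compounds to lie beyond the scatter. On this shared core, the position therefore does not treat these two carbon groups alike, although a single pair cannot show how general that is. Nothing available explains the difference between propyl and cyclohexyl.

This one swap changes both the size of the group and the presence of a ring, so it cannot tell which of the two matters. From the compounds shown here alone, a butyl chain, which stays open, or a cyclopentyl ring, which is smaller than cyclohexyl, on the same nitrogen would help separate them.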